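Sulfonyl substituent exchange from compound 2 to compound 3

The source may hold more compounds than are shown below. What is called first, only, known or untested is meant among the compounds shown, and "the series" means these compounds.

- compound 1 `CNCc1cc(-c2cccnc2F)n(S(=O)(=O)c2ccccn2)c1` - "not determined" (no result reported)
- compound 2 `CNCc1cn(S(=O)(=O)c2cc(OC)ccn2)c(-c2cccnc2F)c1F` - 38 ng.h/mL

Among the compounds with values here, in an ADME assay on the whole organism (plasma, Rattus norvegicus, strain Sprague-Dawley) for pharmacokinetics, read by LC-MS, using cassette dosing, at a dose of 0.2 mg/kg by the intravenous route (on this read-out higher numbers stand for higher exposure at the dose given and lower numbers for lower exposure), compound 2 gives 38 ng.h/mL as the only number so far. Compound 1 has no reported result, so compound 2 cannot yet be ranked against anything. Compound 3 `CNCc1cn(S(=O)(=O)c2ccc(F)cn2)c(-c2cccnc2F)c1F` differs from compound 2 in one group (5-fluoropyridin-2-yl in place of 4-methoxypyridin-2-yl on a sulfonyl sulfur), with 5-fluoropyridin-2-yl in place of 4-methoxypyridin-2-yl on a sulfonyl sulfur. Within the data shown here, no measured pair shows what such an exchange does in this assay, so no step beyond the usual scatter is expected, and no direction is favoured. Among the measured compounds shown here, the sole anchor is compound 2 at 38 ng.h/mL and the range is kept wide for that reason. The expected change is a 1.1-fold higher number from compound 2 to compound 3 (0.02 log units; within the scatter) and remains an estimate. For compound 3 the estimated value is 40 ng.h/mL with an expected range from 15 ng.h/mL to 105 ng.h/mL in this read-out.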

Compound 3, area under the concentration-time curve: 22 ng.h/mL
Compound 3: middle estimate off by 1.8-fold (0.26 log units), on the high side; measured number inside the range.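

In this assay, within the data shown here, the exchange of 4-methoxypyridin-2-yl for 5-fluoropyridin-2-yl on a sulfonyl sulfur gives a 1.7-fold lower number from compound 2 to compound 3 (0.24 log units; within the scatter) and is the first step that can be read at this position. On this single pair, compound 2 and compound 3 cannot be separated, so the exchange shows no effect on exposure that stands clear of repeated-measurement noise. Nothing measured here bears on the origin of this step.

A single exchange does not show how far this position can be changed before exposure moves beyond the scatter. On these data alone, it remains open whether a sulfonyl substituent carrying an amine or a carboxylic acid in place of the methoxy group or the fluorine would give a clearer step, and in which direction.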